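This account rests on a few compounds, and the source may have more. Where it says the series, first, only, none or still open, it means among the compounds named here.

Measured in a functional assay on MV4-11 cells (Homo sapiens) for inhibition, read by resazurin assay, with a stated time of 72 h; on this read-out higher numbers stand for weaker inhibition of growth and lower numbers for stronger inhibition of growth:
Compound 1, `COc1ccc(Nc2nccc(-c3cn(C4CCCC4)c4ccccc34)n2)c(OC)c1`, gives 1740 nM.
Compound 2, `COc1ccc(Nc2nccc(-c3sc(N(C)C)nc3C)n2)c(OC)c1`, gives 170 nM.
Compound 3, `COc1ccc(Nc2nccc(-c3cn(C(C)C)c4ccccc34)n2)c(OC)c1`, gives 3250 nM.

Among these three, compound 2 stands lowest in this assay, and compounds 1 and 3, which share a core different from that of compound 2, both sit well above it, beyond the scatter. Among the compounds with values here, the only step measured between compounds that differ in one place, a 1.9-fold higher number from compound 1 to compound 3 (0.27 log units; within the scatter), concerns the group on the aromatic nitrogen of that other core and says nothing about the five-membered ring found in compound 2.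

Compound 4, `COCCSc1nc(C)c(-c2ccnc(Nc3ccc(OC)cc3OC)n2)s1`, keeps the core of compound 2 and differs from it by one change: (2-methoxyethyl)sulfanyl in place of dimethylamino on an aromatic carbon. Within the data shown here, no measured pair shows this exchange, or any exchange on that ring, so no step bears on it and the only anchor is the number of compound 2. With no guide from the measured steps, a modest step in this assay is expected, if any, with a wide range to cover the uncertainty. Compound 4 is therefore estimated at 350 nM, between 100 nM and 1200 nM. That estimate means a 2.1-fold higher number from compound 2 to compound 4 (0.31 log units; beyond the scatter), and it is held loosely.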

Compound 4, concentration for 50% growth inhibition: 810 nM
Compound 4: middle estimate off by 2.3-fold (0.36 log units), on the low side, within the range that was stated.
By their numbers in this assay, from the lowest: compound 2; then compound 4; then compounds 1 and 3 (each within the scatter of the next).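

Exchanging dimethylamino for (2-methoxyethyl)sulfanyl on the aromatic carbon next to the ring nitrogen and next to the ring sulfur gives a 4.8-fold higher number from compound 2 to compound 4 (0.68 log units; beyond the scatter) in this assay and so provides the first measured sign that this position on the five-membered ring is sensitive to the group it carries. The entering group, with 5 heavy atoms in place of 3, goes with weaker inhibition of growth here, but this single pair cannot tell whether the sulfur attached to the ring or the chain behind it accounts for the change. No measurement shown here gives a reason for this step.

From the compounds shown here alone, it remains open whether a plain methylsulfanyl group, which keeps the sulfur without the longer chain, would stand nearer to compound 2 or to compound 4. Going by these compounds, it is also open how a cyclic amine such as morpholine or a simple primary amine would behave at this position, and whether a larger amine would keep the number of compound 2.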